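Hydroxycarbamoyl versus methylcarbamoyl chain ends: working notes

A few compounds are considered here, and "the series" means these few. Any claim that something is new, unique, unknown or untested is made for them only; others in the source may bear on it.

Measured in a functional assay on SNU-423 cells (Homo sapiens) for inhibition, read by MTT assay, with a stated time of 72 h; on this read-out higher numbers stand for weaker inhibition and lower numbers for stronger inhibition:
- compound 1 `Nc1ncnc2c1c(-c1cnc3[nH]ccc3c1)nn2CCCCCCC(=O)NO`: 7500 nM
- compound 2 `Nc1nc2cc(-c3nn(CCCCC(=O)NO)c4ncnc(N)c34)ccc2o1`: 3030 nM
- compound 3 `CNC(=O)CCCCCCCn1nc(-c2ccc3oc(N)nc3c2)c2c(N)ncnc21`: 280 nM

Compound 3 has the lowest number of the three at 280 nM, and the nearest number belongs to compound 2 at 3030 nM. Compound 4 `Nc1nc2cc(-c3nn(CCCCCCC(=O)NO)c4ncnc(N)c34)ccc2o1` differs from compound 3 by hydroxycarbamoyl in place of (methylcarbamoyl)methyl on a saturated chain carbon, six bonds along the chain from an aromatic nitrogen.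

For the measured compounds named here, the one measured step that bears on this is an 11-fold lower number from compound 2 to compound 3 (1.03 log units; beyond the scatter), which is large and beyond the scatter. It starts from hydroxycarbamoyl placed four bonds along the chain, not six, so it is only a partial guide. Compound 1, which also carries hydroxycarbamoyl, sits high at 7500 nM. Both hydroxycarbamoyl compounds therefore point to a higher number in this assay, though the size is uncertain. The expected change is a 2.9-fold higher number from compound 3 to compound 4 (0.46 log units; beyond the scatter), probably smaller than the measured step. For compound 4 the estimate is 800 nM, with an expected range of 150 nM to 4000 nM.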

Compound 4, half-maximal inhibitory concentration: 6100 nM
The estimate for compound 4 lay 7.6-fold (0.88 log units) below the measured number; the whole stated range lies below it.
By their numbers in this assay, from the lowest: compound 3; then compounds 2, 4 and 1 (each within the scatter of the next, the first and the last beyond it).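

In this assay, the swap at this position gives a 22-fold higher number from compound 3 to compound 4 (1.34 log units; beyond the scatter) with the shared core unchanged, although the end group and chain length change together in this step. Among the hydroxycarbamoyl compounds, the two chain lengths are not separated (a 2.0-fold higher number from compound 2 to compound 4 (0.30 log units; within the scatter)). The two aromatic groups on the core are not separated either (a 1.2-fold lower number from compound 1 to compound 4 (0.09 log units; within the scatter)), so compounds 1, 2 and 4 offer no sign that chain length or aromatic group accounts for the low number of compound 3.

No measurement at hand explains the gap between compound 3 and compound 4. On these data alone, it remains open whether the difference follows the methylcarbamoyl end itself or the longer chain, and how a primary amide or a carboxylic acid at the chain end would read out on the same core.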